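The source may report more compounds than this note shows. Statements on the series, on what has been measured and on what is new or still open speak of the compounds shown alone.

Working notes on the series. Three measured compounds share one core. In an in vitro assay on HEK-tsA201 cells for antagonist activity at Neuronal acetylcholine receptor; alpha3/beta4 (Homo sapiens), read by fluorescence and calcium flux (on this read-out higher numbers stand for weaker inhibition and lower numbers for stronger inhibition), compound 1 `C=CCOc1ccc(C(=O)Nc2cccc(Br)n2)cc1` gives 65500 nM. Compound 2 `CCCOc1ccc(C(=O)Nc2cnccn2)cc1` gives 22500 nM in this assay, and compound 3 `CCCOc1ccc(C(=O)Nc2cccc(CC)n2)cc1` gives 29200 nM. Compound 3 stands second highest of the three numbers: the gap to compound 2 lies within the scatter, so no order is read between those two, while compound 1 sits at a higher number by a gap beyond the scatter.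

Compound 4 `CCCOc1ccc(C(=O)Nc2cccc(Nc3ccc(OC)cc3)n2)cc1` has not been measured in this assay. It differs from compound 3 in one place: (4-methoxyphenyl)amino in place of ethyl on an aromatic carbon.

Within the data shown here, no step between two measured compounds is available, so the size of such a change is not known from this set. The step from compound 3 to compound 4 is expected to be a 1.9-fold lower number from compound 3 to compound 4 (0.29 log units; within the scatter), a move toward a lower number that may not clear the scatter. In this assay compound 4 is expected to give about 15000 nM, with a range from 4000 nM to 60000 nM, the wide span reflecting that all measured numbers, including compound 3 at 29200 nM, lie at weak inhibition.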

Compound 4, half-maximal inhibitory concentration: > 100000 nM
Compound 4 ended at the assay's limit; the forecaster's own chance of this, stated with the estimate: 10%; at least 6.6-fold (0.82 log units) between middle value and limit.
By their numbers in this assay, from the lowest: compounds 2 and 3 (each within the scatter of the next); then compound 1. At a limit, above all of these: compound 4.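

In this assay, the change on an aromatic carbon next to the ring nitrogen gives the first size for a single change in the series: an at least 3.4-fold higher number from compound 3 to compound 4 (0.53 log units; beyond the scatter). This position therefore does not take every group equally: ethyl, with its 2 heavy atoms, retains a measurable value, whereas (4-methoxyphenyl)amino, with 9 heavy atoms and a six-membered aromatic ring, does not. The value of compound 4 is a limit and not a number, so the full size of the step remains unknown: the limit of > 100000 nM in this assay, at which 1 of the 4 values shown sits.

A single change cannot show whether the loss follows the aromatic ring, the linking nitrogen or the methoxy group. A plain amino group, a phenyl ring joined directly to this carbon or an unsubstituted phenylamino group at the same position would separate these parts.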